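A Seven-Membered Amine Ring on the Shared Core

The source may report more compounds than this note shows. Statements on the series, on what has been measured and on what is new or still open speak of the compounds shown alone.

Measured compounds in an assay on isolated protein for displacement of a labelled ligand from melanin-concentrating hormone receptor 1 (Homo sapiens); a lower number here means a stronger inhibitor, a higher number a weaker inhibitor:
compound 1 `CN(c1ccc2cc(NC(=O)CCc3ccc(C(F)(F)F)cc3)ccc2n1)C1CCCC1` gives 2 nM
compound 2 `CC1CCN(c2ccc3cc(NC(=O)CCc4ccc(C(F)(F)F)cc4)ccc3n2)C1` gives 2 nM
compound 3 `Nc1ccc2cc(NC(=O)CCc3ccc(C(F)(F)F)cc3)ccc2n1` gives 240 nM

Compound 2 stands level with compound 1, the two together giving the lowest numbers of the three; the step of no change at the digits printed from compound 1 to compound 2 (within the scatter) lies within the scatter. Compound 3 is the furthest away, as the step of a 120-fold higher number from compound 2 to compound 3 (2.08 log units; beyond the scatter) shows.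

Compound 4 `O=C(CCc1ccc(C(F)(F)F)cc1)Nc1ccc2nc(N3CCCCCC3)ccc2c1` has not yet been measured. It differs from compound 2 in one place: azepan-1-yl in place of 3-methylpyrrolidin-1-yl on an aromatic carbon

Going by the values given here, two measured steps bear on this change. The step of no change at the digits printed from compound 1 to compound 2 (within the scatter) shows that exchanging one ring-bearing amine for another at this position made no difference beyond the scatter. The step of a 120-fold higher number from compound 2 to compound 3 (2.08 log units; beyond the scatter) shows that replacing the ring-bearing amine with a plain amino group cost a great deal. Compound 4 keeps a ring-bearing amine at this position, so the expected step is a 1.5-fold higher number from compound 2 to compound 4 (0.18 log units; within the scatter), that is, no change beyond the scatter. Compound 4 is therefore estimated at 3 nM, within a range from 1 nM to 12 nM.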

Compound 4, half-maximal inhibitory concentration: 36 nM
The estimate for compound 4 lay 12-fold (1.08 log units) below the measured number; measured number outside the range, above it.
By their numbers in this assay, from the lowest: compounds 1 and 2 (each within the scatter of the next); then compound 4; then compound 3.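

The earlier pair suggested that one ring-bearing amine could stand in for another at this position, but in this assay azepan-1-yl does not behave that way: the seven-membered ring gives an 18-fold higher number from compound 2 to compound 4 (1.26 log units; beyond the scatter) and an 18-fold higher number from compound 1 to compound 4 (1.26 log units; beyond the scatter). It still outperforms the plain amino group, with a 6.7-fold lower number from compound 3 to compound 4 (0.82 log units; beyond the scatter), so the choice of amine here matters in degrees, and carrying a ring is not enough on its own to reach the lowest numbers. No measurement available here accounts for the gap between these ring-bearing amines.

The compounds shown leave open whether the numbers climb steadily with ring size or azepan-1-yl is a lone exception. Piperidine or unsubstituted pyrrolidine at the same carbon would help separate ring size from the methyl group of compound 2.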